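This account rests on a few compounds, and the source may have more. Where it says the series, first, only, none or still open, it means among the compounds named here.

Among the compounds with values here, in a functional assay on A549 cells (Homo sapiens) for antiproliferative activity, read by MTT assay, with a stated time of 48 h (on this read-out higher numbers stand for weaker inhibition and lower numbers for stronger inhibition), compound 2 (`CCCCCCOc1ccc(C(=O)/C=C/c2c(/C=C/c3ccc(OC)cc3)cc(OC)cc2OC)cc1`) gives 8.4 ug/mL, the higher of the two numbers measured so far, while compound 1 (`COc1ccc(/C=C/c2cc(OC)cc(OC)c2/C=C/C(=O)c2ccc(C)cc2)cc1`) gives 3.6 ug/mL. Compound 3 (`COc1ccc(/C=C/c2cc(OC)cc(OC)c2/C=C/C(=O)c2ccc(F)cc2)cc1`) has fluoro in place of hexyloxy on an aromatic carbon, para to a large group: fluoro in place of hexyloxy on an aromatic carbon. Within the data shown here, only one measured step bears on this change, a modest one at the same place: a 2.3-fold higher number from compound 1 to compound 2 (0.37 log units; beyond the scatter), with hexyloxy in place of methyl. No measurement with fluoro at this place exists yet. Taking that step as the guide, the loss of hexyloxy is expected to give a step of similar size in the opposite direction, towards a lower number in this assay. The expected change is a 2.1-fold lower number from compound 2 to compound 3 (0.32 log units; beyond the scatter). The estimate for compound 3 is 4 ug/mL, with an expected range of 1.8 ug/mL to 9 ug/mL.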

Compound 3, half-maximal inhibitory concentration: 6.6 ug/mL
Compound 3: the middle estimate sits 1.7-fold (0.22 log units) below what was measured, within the range that was stated.
By their numbers in this assay, from the lowest: compounds 1, 3 and 2 (each within the scatter of the next, the first and the last beyond it).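

In this assay the replacement of hexyloxy by fluoro on this aromatic carbon, para to a large group, gives a 1.3-fold lower number from compound 2 to compound 3 (0.10 log units; within the scatter) and the replacement of methyl by fluoro gives a 1.8-fold higher number from compound 1 to compound 3 (0.26 log units; within the scatter) and so both steps to fluoro stay within the scatter. The earlier compounds shown here showed only that methyl and hexyloxy at this place stand apart, whereas fluoro cannot be told from either of them, so the three groups do not form a clear order in this assay beyond the gap between compound 1 and compound 2. Nothing measured here accounts for these numbers.

The compounds shown leave open how an amine, a carboxylic acid or a chain longer than hexyloxy would behave at this carbon. They also leave open whether a group such as nitrile would move the number beyond the scatter from compound 1.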